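The source may hold more compounds than are shown below. What is called first, only, known or untested is meant among the compounds shown, and "the series" means these compounds.

Working notes on the series. In a functional assay on A549 cells (Homo sapiens) for cytotoxicity, read by MTT assay, with a stated time of 48 h (a lower number here means a stronger inhibitor, a higher number a weaker inhibitor), compound 1 `CNC(=O)CC[C@H](NS(=O)(=O)c1ccc([N+](=O)[O-])cc1)C(=O)O` reaches only a limit of the assay, > 500000 nM. Compound 2 `CCNC(=O)CC[C@H](NS(=O)(=O)c1ccc([N+](=O)[O-])cc1)C(=O)O` gives 221000 nM in this assay. Compound 3 `CCCCCNC(=O)CC[C@H](NS(=O)(=O)c1ccc([N+](=O)[O-])cc1)C(=O)O` gives 206000 nM in this assay. Of the two numbers on hand, compound 2 holds the highest, and its nearest neighbour is compound 3, at a 1.1-fold lower number from compound 2 to compound 3 (0.03 log units; within the scatter). The move away from the limit of compound 1 is an at least 2.2-fold lower number from compound 1 to compound 2 (0.35 log units; beyond the scatter) and an at least 2.4-fold lower number from compound 1 to compound 3 (0.38 log units; beyond the scatter).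

Compound 4 `O=C(CC[C@H](NS(=O)(=O)c1ccc([N+](=O)[O-])cc1)C(=O)O)NCc1ccccc1` differs from compound 2 by phenyl in place of methyl on a saturated chain carbon bound to an amide-type nitrogen. For the measured compounds named here, the steps that bear on this are an at least 2.2-fold lower number from compound 1 to compound 2 (0.35 log units; beyond the scatter) and an at least 2.4-fold lower number from compound 1 to compound 3 (0.38 log units; beyond the scatter), both at least modest when a carbon chain enters at that carbon, and a 1.1-fold lower number from compound 2 to compound 3 (0.03 log units; within the scatter), which shows that adding further carbons past the first one changes nothing beyond the scatter. For compound 4 the expected step is therefore a 1.5-fold lower number from compound 2 to compound 4 (0.17 log units; within the scatter), a lower number at most by a small margin. Compound 4 is estimated at 150000 nM, with a range from 60000 nM to 400000 nM.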

Compound 4, half-maximal inhibitory concentration: 343000 nM
For compound 4 the middle estimate is 2.3-fold (0.36 log units) below the measured one, within the range that was stated.
By their numbers in this assay, from the lowest: compounds 3, 2 and 4 (each within the scatter of the next). At a limit, above all of these: compound 1.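

Phenyl in place of methyl on the saturated chain carbon bound to the amide-type nitrogen brings an aromatic ring into this position for the first time, and the result stays within the scatter of the alkyl chains: a 1.6-fold higher number from compound 2 to compound 4 (0.19 log units; within the scatter), and a 1.7-fold higher number from compound 3 to compound 4 (0.22 log units; within the scatter). In this assay, this position therefore tolerates the change from ethylamino to benzylamino without a readable shift in either direction. The remaining step starts from a limit and reads an at least 1.4-fold lower number from compound 1 to compound 4 (0.16 log units; that floor lies within the scatter), so, unlike the alkyl chains, the benzyl compound is not shown to lie clear of that limit, and the reading is bounded by this: the limit of > 500000 nM in this assay, at which 1 of the 4 values shown sits.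

Open, from the compounds shown here alone, is whether a basic amine or a carboxylic acid at this carbon would move the number beyond the scatter. Also open, going by these compounds, is whether a substituted phenyl ring, such as one bearing a methoxy group, would do so.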